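A Methoxyphenyl Exchange on an Ethenyl Side Chain

This account rests on a few compounds, and the source may have more. Where it says the series, first, only, none or still open, it means among the compounds named here.

Three related compounds are considered here. In a functional assay on HeLa cells (Homo sapiens) for cytotoxicity, read by MTT assay, with a stated time of 72 h (on this read-out lower numbers stand for stronger inhibition and higher numbers for weaker inhibition), compound 1 (`COc1ccc(/C=C/C(=O)Nc2cc3c(Nc4ccc(F)c(Cl)c4)ncnc3cc2OC)cc1`) has the entry "not determined" (no result reported) and so offers no number for comparison. For the measured compounds named here, compound 2 (`COc1cc(/C=C/C(=O)Nc2cc3c(Nc4ccc(F)c(Cl)c4)ncnc3cc2O[C@H]2CCOC2)cc(OC)c1`) gives 34300 nM as the only number available, so it cannot yet be ranked against another compound. Compound 3 (`COc1ccc(/C=C/C(=O)Nc2cc3c(Nc4ccc(F)c(Cl)c4)ncnc3cc2O[C@H]2CCOC2)cc1`) has still to be measured in this assay and differs from compound 2 by one exchange (4-methoxyphenyl in place of 3,5-dimethoxyphenyl on a double-bonded chain carbon bound to a double-bonded chain carbon). Here 4-methoxyphenyl stands in place of 3,5-dimethoxyphenyl on a double-bonded chain carbon bound to a double-bonded chain carbon. Going by the values given here, no measured pair shows the effect of this exchange, so no step beyond the usual scatter is expected, in either direction. The estimate puts a 1.1-fold lower number from compound 2 to compound 3 (0.06 log units; within the scatter) inside that scatter. Compound 3 is expected at 30000 nM (estimated range 10000 nM to 80000 nM).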

Compound 3, half-maximal inhibitory concentration: 34600 nM
Beside the measured number, compound 3's estimate is 1.2-fold (0.06 log units) below it; the range from low to high includes it.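

In this assay, for the compounds shown here, the exchange of 3,5-dimethoxyphenyl for 4-methoxyphenyl on a double-bonded chain carbon bound to a double-bonded chain carbon gives a 1.0-fold higher number from compound 2 to compound 3 (0.00 log units; within the scatter), the first measured step at this position. On this read-out the two groups cannot be told apart, so this position tolerates this particular change without a step beyond the usual scatter. Nothing at hand accounts for this result.

Compound 1 carries no number, so the step from it to compound 3, at the other place where those two differ, cannot be read. From the compounds shown here alone, whether an amine or a carboxylic acid in place of the methoxyphenyl group, or a longer chain in place of the ethenyl link, would shift the number remains open.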